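The source may hold more compounds than are shown below. What is called first, only, known or untested is meant among the compounds shown, and "the series" means these compounds.

For the measured compounds named here, in a physicochemical assay for lipophilicity, using the shake flask method, in phosphate buffer, measured as octanol-water partition, with a stated time of 5 h, at pH 7.4 (on this read-out higher numbers stand for higher lipophilicity and lower numbers for lower lipophilicity), compound 1 `CN1CCN(c2cc(Nc3ncc(Br)c(Nc4cccc(CO)c4)n3)cc(S(C)(=O)=O)c2)CC1` gives 2.43, the highest of the three numbers measured so far. Compound 4 `Cc1cnc(Nc2cc(N3CCN(C)CC3)cc(S(C)(=O)=O)c2)nc1Nc1cccc(CO)c1` has not yet been measured. It keeps the large group of compound 1 and changes one small substituent: methyl in place of bromo on an aromatic carbon. Going by the values given here, no measured pair isolates this swap. Among the compounds with values here, the only measured step, a number 0.92 log units lower from compound 2 to compound 3 (beyond the scatter), changes the large group while methyl stays in place, so it shows how far a change elsewhere can move the read-out, but not how bromo compares with methyl. Two methyl compounds offer indirect guidance: compound 2 `CC(=O)N1CCN(c2cc(Nc3ncc(C)c(Nc4cccc(CO)c4)n3)cc(S(C)(=O)=O)c2)CC1` at 1.74 and compound 3 `Cc1cnc(Nc2cc(N3C[C@@H]4C[C@H]3CN4C)cc(S(C)(=O)=O)c2)nc1Nc1cccc(CO)c1` at 0.82 both lie under compound 1, although each also differs from it in the large group. A modest drop is therefore expected, smaller than the gap between compound 2 and compound 3. The estimated change is a number 0.43 log units lower from compound 1 to compound 4 (beyond the scatter). For compound 4 the expected value is 2, with an estimated range from 1.6 to 2.4.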

Compound 4, distribution coefficient: 1.74
Compound 4: middle estimate off by 0.26 log units, on the high side, within the range that was stated.
By their numbers in this assay, from the lowest: compound 3; then compounds 2 and 4 (each within the scatter of the next); then compound 1.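

In this assay the swap of bromo for methyl on this aromatic carbon can now be read on its own: it gives a number 0.69 log units lower from compound 1 to compound 4 (beyond the scatter) with nothing else in the structure changed. With methyl held in place, changing the large group also counts, since the one-ring group in place of the two-ring group gives a number 0.92 log units higher from compound 3 to compound 4 (beyond the scatter) in the same read-out. For the compounds shown here, a smaller edit on that group, methyl in place of acetyl on the amine nitrogen in the ring, gives no change at the digits printed from compound 2 to compound 4 (within the scatter) and so leaves no step to read.

Nothing measured here explains the size of these steps. The compounds shown leave open how chloro, methoxy or an amine on this aromatic carbon would compare with bromo and methyl, and whether the bromo-to-methyl step keeps its size with the large group of compound 2 or compound 3.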